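Removing a Methyl From the Amine of Compound 1

A few compounds are considered here, and "the series" means these few. Any claim that something is new, unique, unknown or untested is made for them only; others in the source may bear on it.

Compound 1 `CN(Cc1ccc(Br)cc1OC(F)(F)F)CC1CCC(CNc2nc(N(C)C)c3ccccc3n2)CC1` is the weakest of the three measured compounds in an assay on HEK293 cells for inhibition of melanin-concentrating hormone receptor 1 (Homo sapiens), read by radioligand binding (a lower number here means a stronger inhibitor, a higher number a weaker inhibitor), where compound 1 gives 5600 nM. Compound 2 `CN(C)c1nc(N[C@H]2CC[C@@H](NC(=O)c3ccccc3F)CC2)nc2ccccc12` gives 170 nM and compound 3 `CN(C)c1nc(N[C@H]2CC[C@@H](NC(=O)c3cccc(Cl)c3)CC2)nc2ccccc12` gives 4.5 nM. Going by the values given here, the only measured step is a 38-fold lower number from compound 2 to compound 3 (1.58 log units; beyond the scatter), which concerns the aryl group on an amide and not the amine part of compound 1, so it offers no guide here. Compound 4 `CN(C)c1nc(NCC2CCC(CNCc3ccc(Br)cc3OC(F)(F)F)CC2)nc2ccccc12` differs from compound 1 by hydrogen in place of methyl on an amine nitrogen. Among the compounds with values here, with no measured step bearing on this change, compound 4 is expected to stay close to compound 1, with an estimated step of a 1.1-fold lower number from compound 1 to compound 4 (0.05 log units; within the scatter) that lies within the scatter. Compound 4 is therefore estimated at 5000 nM, with a range from 1500 nM to 16000 nM.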

Compound 4, half-maximal inhibitory concentration: 960 nM
Compound 4: middle estimate off by 5.2-fold (0.72 log units), on the high side; measured number outside the range, below it.
By their numbers in this assay, from the lowest: compound 3; then compound 2; then compound 4; then compound 1.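

This amine nitrogen, whose other neighbours are two saturated chain carbons, responds to a very small edit: in this assay hydrogen in place of methyl gives a 5.8-fold lower number from compound 1 to compound 4 (0.77 log units; beyond the scatter) and so removes only one carbon yet moves the number beyond the scatter. Going by these compounds alone, none of the earlier compounds tested this position. Nothing shown here explains the change.

From the compounds shown here alone, what an ethyl group, a longer chain or an acetyl group on this nitrogen would do remains open. So does whether removing this methyl would have the same effect with a different aryl group.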